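Swapping an Octyl Chain for a Trifluoromethylphenyl Ring

The compounds below may be only part of what the source reports. "The series", "measured", "known", "first", "only" and "open" are said of these compounds alone.

Compound 2 `CCCCCCCCc1cn(C(c2ccccc2)c2cc3cc(Br)ccc3nc2OC)nn1` is the starting point. In an ADME assay on PANC-1 cells (Homo sapiens) for cytotoxicity, read by sulforhodamine B assay, with a stated time of 48 h, tested at 10 uM (a lower number here means less inhibition, a higher number more inhibition at the concentration tested (going by the name of the read-out)), compound 2 gives 12.1%. Among the three measured compounds this is the second highest number: the step of a number 7 percentage points lower from compound 2 to compound 3 (within the scatter) stays within the usual scatter, while compound 1 `COc1nc2ccc(Br)cc2cc1C(c1ccccc1)n1cc(-c2ccccc2)nn1` gives 30.1% and the step of a number 18 percentage points lower from compound 1 to compound 2 (beyond the scatter) lies beyond it. Compound 3 `CCCCCc1cn(C(c2ccccc2)c2cc3cc(Br)ccc3nc2OC)nn1` gives 5.07% in this assay.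

Compound 4 `COc1nc2ccc(Br)cc2cc1C(c1ccccc1)n1cc(-c2ccccc2C(F)(F)F)nn1` differs from compound 2 in one place: 2-(trifluoromethyl)phenyl in place of octyl on an aromatic carbon.

The measured step that bears most on this change is a number 18 percentage points lower from compound 1 to compound 2 (beyond the scatter), where the same octyl chain took the place of a phenyl ring and inhibition fell. For the measured compounds named here, the present change goes the other way, putting an aromatic ring back where the chain sits, though this ring now carries a trifluoromethyl group, and no measured pair shows what that group adds. The step of a number 25 percentage points lower from compound 1 to compound 3 (beyond the scatter) points the same way as the first: a chain in place of the ring gives lower inhibition. A rise back towards the number of compound 1 is therefore expected, a number 15.9 percentage points higher from compound 2 to compound 4 (beyond the scatter). The estimate for compound 4 in this assay is 28%, with a range from 12% to 45%.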

Compound 4, a percentage reported as inhibition, at one concentration (the size of the read-out at that concentration, not a potency): 11.4%
Compound 4: middle estimate off by 16.6 percentage points, on the high side; the measured number lies below the stated range.
By their numbers in this assay, from the lowest: compounds 3, 4 and 2 (each within the scatter of the next); then compound 1.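

In this assay the results for 2-(trifluoromethyl)phenyl at this position cannot be told apart from those for the two chains: a number 0.7 percentage points lower from compound 2 to compound 4 (within the scatter) against octyl and a number 6.3 percentage points higher from compound 3 to compound 4 (within the scatter) against pentyl show that a ring bearing this group does no more here than a chain does. The plain phenyl ring of compound 1 does stand apart, and a number 18.7 percentage points lower from compound 1 to compound 4 (beyond the scatter) for trifluoromethyl in place of hydrogen on an aromatic carbon shows that having a ring at this position does not by itself carry the higher number: what the ring bears counts as well. Nothing shown here explains the fall that comes with this one added group.

For the compounds shown here, only one substituted phenyl ring appears, so it stays open whether the fall belongs to trifluoromethyl itself or would also come with a methyl group, a chlorine atom or a methoxy group in its place. The chains leave a similar gap, and a chain ending in an amine at this position would test whether anything other than a plain phenyl ring can climb back towards compound 1.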